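A new side group for compound 2

This account rests on a few compounds, and the source may have more. Where it says the series, first, only, none or still open, it means among the compounds named here.

In a functional assay on MDA-MB-453 cells (Homo sapiens) for antiproliferative activity, read by MTT assay, with a stated time of 72 h (a higher number here means a weaker inhibitor, a lower number a stronger inhibitor), compound 1 `CCOC(=O)c1c[nH]nc1N/C=C1\C(=O)NN=C1c1ccccc1` gives 74600 nM, and compound 2 `CCOC(=O)c1c[nH]nc1N/C=C1\C(=O)N(c2ccccc2)N=C1c1ccccc1` gives 19400 nM. Compound 2 therefore holds the lower of the two numbers and is the stronger inhibitor of this pair. Among the measured compounds shown here, the only measured step, a 3.8-fold lower number from compound 1 to compound 2 (0.58 log units; beyond the scatter), came with phenyl in place of hydrogen on an amide-type nitrogen in a ring.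

Compound 3 `CSCC[C@H](N/C=C1\C(=O)N(c2ccccc2)N=C1c1ccccc1)C(=O)O` keeps that phenyl and differs from compound 2 elsewhere: 1-carboxy-3-(methylsulfanyl)propyl stands in place of 4-(ethoxycarbonyl)-1H-pyrazol-3-yl on an amine nitrogen (1-carboxy-3-(methylsulfanyl)propyl in place of 4-(ethoxycarbonyl)-1H-pyrazol-3-yl on an amine nitrogen). For the measured compounds named here, no measured compound shows what a change at this place does, so the earlier step offers only a rough yardstick of size, and a modest one. The direction cannot be read from the data, and the range must stay wide on both sides. A modest move toward a weaker inhibitor is the cautious expectation, and the estimated change is a 2.1-fold higher number from compound 2 to compound 3 (0.31 log units; beyond the scatter). Compound 3 is expected at 40000 nM, with an estimated range from 12000 nM to 130000 nM.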

Compound 3, half-maximal inhibitory concentration: 9430 nM
Estimate against measurement, compound 3: 4.2-fold (0.63 log units) above, outside the stated range (below it).
By their numbers in this assay, from the lowest: compound 3; then compound 2; then compound 1.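

This position on the amine nitrogen turns out to accept a very different group: in this assay, replacing 4-(ethoxycarbonyl)-1H-pyrazol-3-yl with 1-carboxy-3-(methylsulfanyl)propyl gives a 2.1-fold lower number from compound 2 to compound 3 (0.31 log units; beyond the scatter) and so leads to the strongest inhibitor of the three. Up to now, every measured compound carried the five-membered aromatic ring at this place, and compound 3 shows that, on the shared core with its phenyl, a group with no ring can do better in this assay, so that ring is not required for the activity seen here. No measurement shown here explains why the open chain gives the lower number.

Among the compounds shown here, the single step also cannot show which part of the new chain matters, since the carboxy group, the methylsulfanyl end and the defined stereocentre all arrive together. From the compounds shown here alone, a hydroxyl group in place of the methylsulfanyl end, a primary amide in place of the carboxy group, or the opposite configuration at the stereocentre would each test one of these parts, and the outcome of each remains open.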